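Indole substituent swap in a benzhydrylpiperazine series

The compounds below may be only part of what the source reports. "The series", "measured", "known", "first", "only" and "open" are said of these compounds alone.

Compound 3 `Cc1cccc2ccn(CCCCN3CCN(C(c4ccccc4)c4ccccc4)CC3)c12` gives 2300 nM in an assay on RPMI-8226 cells for antagonist activity at P2X purinoceptor 7 (Homo sapiens), read by calcium flux (a higher number here means a weaker inhibitor, a lower number a stronger inhibitor), the highest number of the three measured. Compound 2 `Cc1cc2ncn(CCCCN3CCN(C(c4ccccc4)c4ccccc4)CC3)c2cc1C` gives 770 nM and compound 1 `O=c1[nH]c2ccccc2n1CCCCCN1CCN(C(c2ccccc2)c2ccccc2)CC1` gives 560 nM; the step of a 3.0-fold higher number from compound 2 to compound 3 (0.48 log units; beyond the scatter) and the step of a 4.1-fold higher number from compound 1 to compound 3 (0.61 log units; beyond the scatter) both lie beyond the scatter, while a 1.4-fold higher number from compound 1 to compound 2 (0.14 log units; within the scatter) does not. Compound 4 `COc1ccc2c(ccn2CCCCN2CCN(C(c3ccccc3)c3ccccc3)CC2)c1` carries 5-methoxy-1H-indol-1-yl in place of 7-methyl-1H-indol-1-yl on a saturated chain carbon, four bonds along the chain from an amine nitrogen in a ring. Going by the values given here, no measured step alters a substituent on an indole; the measured steps all exchange the whole ring system, so they do not bear on this change. A step of a 1.3-fold lower number from compound 3 to compound 4 (0.11 log units; within the scatter) is therefore expected, within the scatter. Compound 4 is estimated at 1800 nM in this assay, with a range of 700 nM to 4500 nM.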

Compound 4, half-maximal inhibitory concentration: > 10000 nM
Compound 4: no number, only a limit; the forecaster's own chance of this, stated with the estimate: 5%; middle value at least 5.5-fold (0.74 log units) away from the limit.
By their numbers in this assay, from the lowest: compounds 1 and 2 (each within the scatter of the next); then compound 3. At a limit, above all of these: compound 4.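

Compound 4 stands only as a limit, not as a number: the limit of > 10000 nM in this assay, at which 1 of the 4 values shown sits. Going by these compounds alone, the one substituent change on an indole, 5-methoxy-1H-indol-1-yl in place of 7-methyl-1H-indol-1-yl, gives an at least 4.3-fold higher number from compound 3 to compound 4 (0.63 log units; beyond the scatter), so the substituent matters here, not only the ring system. The whole-ring comparisons are wider, with an at least 12-fold higher number from compound 2 to compound 4 (1.11 log units; beyond the scatter) and an at least 17-fold higher number from compound 1 to compound 4 (1.25 log units; beyond the scatter).

Compound 3 and compound 4 differ in both the substituent and where it sits, so these two effects stay unseparated. An unsubstituted indole, 5-methyl-1H-indol-1-yl or 7-methoxy-1H-indol-1-yl would separate them.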